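A few compounds are considered here, and "the series" means these few. Any claim that something is new, unique, unknown or untested is made for them only; others in the source may bear on it.

Measured compounds in a functional assay on SNB-19 cells (Homo sapiens) for inhibition, read by sulforhodamine B assay, with a stated time of 48 h; a lower number here means a stronger inhibitor of growth, a higher number a weaker inhibitor of growth:
compound 1, `COc1ccc(CNc2nc3cc(N)cc(N)c3nc2-c2ccccc2)cc1OC`, 25700 nM;
compound 2, `Nc1cc(N)c2nc(-c3ccccc3)c(NCc3ccc(F)cc3)nc2c1`, 6610 nM;
compound 3, `COc1ccc(Sc2nc3cc(N)cc(N)c3nc2-c2ccccc2)cc1`, a limit of the assay, < 100000 nM.

Compound 3 stands only at a limit in this assay, as the limit of < 100000 nM in this assay, at which 1 of the 3 values shown sits, records; no number is known for it. Compound 4, `Nc1cc(N)c2nc(-c3ccccc3)c(Oc3ccc(F)cc3)nc2c1`, is not yet measured. From compound 3 the change is 4-fluorophenoxy in place of (4-methoxyphenyl)sulfanyl on an aromatic carbon.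

Within the data shown here, two measured steps bear on this change. The exchange of an aryl group on the side chain, a 3.9-fold lower number from compound 1 to compound 2 (0.59 log units; beyond the scatter), shows that a 4-fluorophenyl in place of a methoxylated phenyl can move the number by a modest amount. The step at the same aromatic carbon, a step that the limit leaves unreadable from compound 2 to compound 3, tells nothing of its size, since compound 3 carries only a limit. Compound 2, with a (4-fluorobenzyl)amino group at that carbon, gives 6610 nM, and compound 4 keeps a 4-fluorophenyl while exchanging the linker atom.

Compound 4 is therefore expected to give a readable number in this assay, around 20000 nM, between 4000 nM and 100000 nM. The step this estimate means from the limit of compound 3 is a step that the limit leaves unreadable from compound 3 to compound 4, an expectation only.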

Compound 4, concentration for 50% growth inhibition: 17400 nM
Estimate against measurement, compound 4: 1.1-fold (0.06 log units) above, and the stated range covers the measured number.
By their numbers in this assay, from the lowest: compound 2; then compounds 4 and 1 (each within the scatter of the next).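

In this assay, the aromatic carbon next to the ring nitrogen now has a readable exchange: 4-fluorophenoxy in place of (4-fluorobenzyl)amino gives a 2.6-fold higher number from compound 2 to compound 4 (0.42 log units; beyond the scatter). Both groups carry a 4-fluorophenyl, so a readable number survives a change in what joins that ring to the core, though the (4-fluorobenzyl)amino group of compound 2 keeps the lower number of the pair. Compound 3 carries only a limit, so the step to compound 4 cannot be read: the limit of < 100000 nM in this assay, at which 1 of the 4 values shown sits.

The compounds shown leave open whether the difference follows the linking oxygen or the chain carbon of the (4-fluorobenzyl)amino group; a 4-fluorobenzyloxy or a 4-fluoroanilino group at this carbon would separate the two. Also open, from the compounds shown here alone, is how a group without an aryl ring, such as a simple alkylamine, would read here.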